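Replacing the piperidine amide with an open-chain ester amide

The compounds below may be only part of what the source reports. "The series", "measured", "known", "first", "only" and "open" are said of these compounds alone.

Measured compounds:
compound 1, `CC1CCCN(C(=O)CN2CN(c3ccccc3)C3(CCN(C(=O)c4ccc(C5CCCCC5)cc4)CC3)C2=O)C1`, 3600 nM
compound 2, `CC1CCCN(C(=O)CN2CN(c3ccccc3)C3(CCN(C(=O)c4ccc(C(C)(C)C)cc4)CC3)C2=O)C1`, 12000 nM
compound 3, `CC(C)(C)OC(=O)NC1CCCN(C(=O)CN2CN(c3ccccc3)C3(CCN(C(=O)c4ccc(C5CCCCC5)cc4)CC3)C2=O)C1`, 4400 nM

All three compounds were tested in an assay on HEK293 cells for displacement of a labelled ligand from NPC1-like intracellular cholesterol transporter 1 (Homo sapiens); a lower number here means a stronger inhibitor, a higher number a weaker inhibitor. Among these three numbers compound 1 has the lowest. Compound 3 sits close to it, with a 1.2-fold higher number from compound 1 to compound 3 (0.09 log units; within the scatter), a difference that is within the scatter. Compound 2 is further away, with a 3.3-fold higher number from compound 1 to compound 2 (0.52 log units; beyond the scatter), a difference beyond the scatter.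

Compound 4, `COC(=O)CCNC(=O)CN1CN(c2ccccc2)C2(CCN(C(=O)c3ccc(C4CCCCC4)cc3)CC2)C1=O`, has not yet been measured in this assay. It differs from compound 1 by (2-(methoxycarbonyl)ethyl)amino in place of 3-methylpiperidin-1-yl on a carbonyl carbon. Going by the values given here, of the measured steps, only the one from compound 1 to compound 3 touches the same end of the molecule, and that step changed a substituent on the saturated ring while keeping the ring; its small size suggests this region tolerates change. The step from compound 1 to compound 2 concerns the opposite end and does not bear on this change. Removing the ring altogether and introducing a chain with a hydrogen-bond donor and two acceptors has no precedent among these compounds, so a modest weakening, a 1.8-fold higher number from compound 1 to compound 4 (0.26 log units; within the scatter), is expected rather than a large one. Compound 4 is therefore estimated at 6500 nM, with a range from 2000 nM to 22000 nM.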

Compound 4, half-maximal inhibitory concentration: 12900 nM
Estimate against measurement, compound 4: 2.0-fold (0.30 log units) below; the range from low to high includes it.
By their numbers in this assay, from the lowest: compounds 1 and 3 (each within the scatter of the next); then compounds 2 and 4 (each within the scatter of the next).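

In this assay, exchanging 3-methylpiperidin-1-yl on the carbonyl carbon for the open-chain (2-(methoxycarbonyl)ethyl)amino group gives a 3.6-fold higher number from compound 1 to compound 4 (0.55 log units; beyond the scatter), which shows that this end of the molecule does respond to change, though the step is modest. The earlier step at this end, a 1.2-fold higher number from compound 1 to compound 3 (0.09 log units; within the scatter), kept the ring and altered only a substituent on it, so the tolerance seen there covers that change and does not extend to this replacement, where the heavy-atom count stays the same while the ring leaves and a hydrogen-bond donor and two hydrogen-bond acceptors enter. Nothing available here links the weaker result to any one of these differences.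

The compounds shown leave open which difference matters: a plain propylamino chain would test the open chain without the methyl ester, while a piperidine ring carrying a methoxycarbonyl group would test the ester with the ring kept. Also open, on these data alone, is whether a carboxylic acid in place of the methyl ester, or a longer chain between the amide nitrogen and the ester, would move the number in either direction.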